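Methyl tetrazole in place of methoxymethyl: working notes

This account rests on a few compounds, and the source may have more. Where it says the series, first, only, none or still open, it means among the compounds named here.

Compound 1 `COCc1cc(-c2ccccc2)c2ccc(OCc3cccc(C4(O)CCOCC4)c3)cc2c1`: 200 nM
Compound 2 `COC(=O)c1cc(-c2ccccc2)c2ccc(OCc3cccc(C4(O)CCOCC4)c3)cc2c1`: 100 nM
Compound 3 `Cn1nnc(-c2cc(-c3ccccc3)c3ccc(OCc4cccc(C5(O)CCOCC5)c4)cc3c2)n1`: 310 nM

In a functional assay (blood) for inhibition, with Homo sapiens as the target (on this read-out lower numbers stand for stronger inhibition and higher numbers for weaker inhibition), compound 1 stands within the scatter of both other compounds, with a 2.0-fold lower number from compound 1 to compound 2 (0.30 log units; within the scatter) and a 1.6-fold higher number from compound 1 to compound 3 (0.19 log units; within the scatter). Only a 3.1-fold higher number from compound 2 to compound 3 (0.49 log units; beyond the scatter) goes beyond it.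

Compound 4 `Cn1nnnc1-c1cc(-c2ccccc2)c2ccc(OCc3cccc(C4(O)CCOCC4)c3)cc2c1` is not yet measured. Its difference is 1-methyl-1H-tetrazol-5-yl in place of methoxymethyl on an aromatic carbon, with 1-methyl-1H-tetrazol-5-yl in place of methoxymethyl on an aromatic carbon. The closest guide is the 2-methyl-2H-tetrazol-5-yl group on that same carbon, which gave a 1.6-fold higher number from compound 1 to compound 3 (0.19 log units; within the scatter). No step beyond the scatter is therefore expected, with any drift towards higher numbers.

The expected step is a 1.5-fold higher number from compound 1 to compound 4 (0.18 log units; within the scatter). The estimate for compound 4 is 300 nM, with an expected range of 120 nM to 750 nM.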

Compound 4, half-maximal inhibitory concentration: > 10000 nM
Compound 4 gave a limit, no number; the forecaster's own chance of this, stated with the estimate: 3%; at least 33-fold (1.52 log units) between middle value and limit.
By their numbers in this assay, from the lowest: compounds 2, 1 and 3 (each within the scatter of the next, the first and the last beyond it). At a limit, above all of these: compound 4.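

In this assay the result for compound 4 is a limit and not a number: the limit of > 10000 nM in this assay, at which 1 of the 4 values shown sits.

Read against that limit, the steps are an at least 50-fold higher number from compound 1 to compound 4 (1.69 log units; beyond the scatter), an at least 32-fold higher number from compound 3 to compound 4 (1.50 log units; beyond the scatter) and an at least 100-fold higher number from compound 2 to compound 4 (2.00 log units; beyond the scatter). At this aromatic carbon, the choice between the 1-methyl-1H-tetrazol-5-yl and 2-methyl-2H-tetrazol-5-yl groups therefore matters far more than the earlier exchanges among methoxymethyl, methoxycarbonyl and 2-methyl-2H-tetrazol-5-yl had suggested.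

Going by these compounds, how far compound 4 lies past its limit stays open. Also open, on these data alone, is whether an unmethylated tetrazole, a carboxylic acid or a primary amide on this carbon would follow compound 3 or compound 4.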